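The compounds below may be only part of what the source reports. "The series", "measured", "known", "first", "only" and "open" are said of these compounds alone.

Measured so far:
compound 1 `CCCCCc1cc2nn(-c3ccccc3)cc2cn1` — in a functional assay on MCF7 cells (Homo sapiens) for inhibition, read by fluorescence, with a stated time of 72 h (a higher number here means a weaker inhibitor of growth, a lower number a stronger inhibitor of growth), compound 1 gives 11800 nM.
compound 2 `c1ccc(-n2cc3cnccc3n2)cc1` — in this assay compound 2 gives > 100000 nM, which is a limit of the assay and not a number.

Compound 2 therefore stands at the limit of > 100000 nM in this assay, at which 1 of the 2 values shown sits; of the two values only compound 1 is a real number. Compound 3 `c1ccc(-n2cc3cnc(C4CC4)cc3n2)cc1` differs from compound 2 by cyclopropyl in place of hydrogen on an aromatic carbon. Within the data shown here, the one measured step that bears on this position is an at least 8.4-fold higher number from compound 1 to compound 2 (0.92 log units; beyond the scatter), the loss of pentyl from the carbon next to the ring nitrogen; it went in the weakening direction and beyond the scatter. Putting a carbon substituent back at the same carbon should move in the opposite direction, but no measurement here covers cyclopropyl, only pentyl, so the size of the step is uncertain and may not be as large as the pentyl case. The estimate for compound 3 in this assay is 30000 nM, within 8000 nM to 100000 nM, which means an expected step of an at least 3.3-fold lower number from compound 2 to compound 3 (0.52 log units; beyond the scatter); a result that again reports only the limit is expected to remain possible.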

Compound 3, concentration for 50% growth inhibition: 69300 nM
Compound 3: the middle estimate sits 2.3-fold (0.36 log units) below what was measured, within the range that was stated.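

In this assay, among these compounds, a carbon substituent on this aromatic carbon is not interchangeable with another: cyclopropyl in place of pentyl gives a 5.9-fold higher number from compound 1 to compound 3 (0.77 log units; beyond the scatter), so the activity of compound 1 does not carry over to every carbon group at this position, which the earlier compounds could not show. Cyclopropyl in place of hydrogen gives an at least 1.4-fold lower number from compound 2 to compound 3 (0.15 log units; that floor lies within the scatter), and since that floor lies within the scatter, these values do not establish how much cyclopropyl gains over hydrogen. Compound 2 stays at a limit of the assay and not a number: the limit of > 100000 nM in this assay, at which 1 of the 3 values shown sits.

The compounds shown cannot separate the effect of chain length from that of the three-membered ring, since pentyl and cyclopropyl differ in both respects; a propyl chain would sit between them on this question, and a heptyl chain would show whether the trend with a longer chain continues. From the compounds shown here alone, whether this carbon accepts anything other than a plain carbon group, such as an amine or a carboxylic acid, also remains open.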